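Cytotoxicity in Kidney Cells: Adding a Fluorine to a Phenyl

A few compounds are considered here, and "the series" means these few. Any claim that something is new, unique, unknown or untested is made for them only; others in the source may bear on it.

Compound 1, `CCCCCCc1cn(C(c2ccccc2)c2cc3cc(Br)ccc3nc2OC)nn1`, in an ADME assay on HEK293 cells (Homo sapiens) for cytotoxicity, read by sulforhodamine B assay, with a stated time of 48 h, tested at 10 uM (a lower number here means less inhibition, a higher number more inhibition at the concentration tested (going by the name of the read-out)), gives -3.17%.
Compound 2, `COc1nc2ccc(Br)cc2cc1C(c1ccccc1)n1cc(-c2ccccc2)nn1`, gives 8.25%.

Among the compounds with values here, compound 2 stands highest of the two numbers measured so far, with compound 1 as its only neighbour; the step of a number 11.4 percentage points higher from compound 1 to compound 2 (beyond the scatter) came with phenyl in place of hexyl on an aromatic carbon and counts as modest. Compound 3, `COc1nc2ccc(Br)cc2cc1C(c1ccccc1)n1cc(-c2ccccc2F)nn1`, is the next compound, and it differs from compound 2 only as follows: fluoro in place of hydrogen on an aromatic carbon. Within the data shown here, no measured step involves a fluorine, so the single known step between compound 1 and compound 2 concerns a different part of the molecule and gives no direct guide. With nothing pointing either way, the expectation is a change within the scatter, a number 1.8 percentage points higher from compound 2 to compound 3 (within the scatter). Compound 3 is therefore estimated at 10%, with a range from -6% to 26%.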

Compound 3, a percentage reported as inhibition, at one concentration (the size of the read-out at that concentration, not a potency): 3.97%
The estimate for compound 3 lay 6 percentage points above the measured number, and the stated range covers the measured number.
By their numbers in this assay, from the lowest: compounds 1, 3 and 2 (each within the scatter of the next, the first and the last beyond it).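

In this assay, fluoro in place of hydrogen on an aromatic carbon, ortho to a large group, gives a number 4.3 percentage points lower from compound 2 to compound 3 (within the scatter), so a single fluorine at this position produces no change that can be told from the scatter. Replacing hexyl with 2-fluorophenyl gives a number 7.1 percentage points higher from compound 1 to compound 3 (within the scatter), so compound 3 lies within the scatter of both earlier compounds, even though compound 1 and compound 2 are separated beyond it. No measurement is available to explain these numbers.

The compounds shown leave open whether an amine or a methoxy group in place of this fluorine would give a number beyond the scatter of compound 2. They also leave open how a butyl chain or a cyclohexyl ring would compare with hexyl and phenyl.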